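The source may report more compounds than this note shows. Statements on the series, on what has been measured and on what is new or still open speak of the compounds shown alone.

Measured compounds:
Compound 1 `COc1cc(-c2ncnn2-c2ccc([N+](=O)[O-])cc2)cc(OC)c1OC` — in a functional assay on HeLa cells (Homo sapiens) for antiproliferative activity, read by MTT assay, with a stated time of 72 h (a lower number here means a stronger inhibitor, a higher number a weaker inhibitor), compound 1 gives > 10000 nM, which is a limit of the assay and not a number.
Compound 2 `COc1cc(-c2ncnn2-c2ccccc2)cc(OC)c1OC` — in this assay compound 2 gives > 10000 nM, again only a limit.
Compound 3 `COc1cc(-n2ncnc2-c2ccccc2)cc(OC)c1OC` — in this assay compound 3 gives > 10000 nM, again only a limit.

Compound 4 `COc1cc(-n2ncnc2-c2cccc([N+](=O)[O-])c2)cc(OC)c1OC` has not been measured. It arises from compound 3 by the change (nitro in place of hydrogen on an aromatic carbon). The same kind of change, though not the same one, has already been made once: compound 1 arises from compound 2 by nitro in place of hydrogen on an aromatic carbon. The two places differ in their surroundings: in compound 4 the nitro sits meta to a large group, in compound 1 para to a large group. The difference between the core of compound 2 and the core of compound 3 is not broken down here.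

The measured step that the two limits leave unreadable from compound 2 to compound 1 cannot be sized, because of the limit of > 10000 nM in this assay, at which 3 of the 3 values shown sit. All three values therefore give no direction. The step that the limit leaves unreadable from compound 3 to compound 4 is accordingly expected to be unreadable as well, and compound 4 is estimated at 20000 nM, between 5000 nM and 80000 nM, most probably reported only as a limit.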

Compound 4, half-maximal inhibitory concentration: > 10000 nM
Compound 4: a limit, no number; the forecaster's own chance of this, stated with the estimate: 85%; the middle value does not contradict the limit.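

No new step can be read from compound 3 to compound 4, and the nitro change stays unsized here as it did from compound 2 to compound 1, because all values rest on one assay ceiling: the limit of > 10000 nM in this assay, at which 4 of the 4 values shown sit.

The compounds shown leave open how strongly any of them acts in this assay, what nitro does to that activity, and how the core of compound 2 compares with the core of compound 3.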